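The compounds below may be only part of what the source reports. "The series", "measured", "known", "first", "only" and "open" are said of these compounds alone.

Measured so far:
compound 1, `O=C(Nc1ccc2nc(Nc3ccc(Cl)c(Cl)c3)c(Nc3ccc(Cl)c(Cl)c3)nc2c1)c1cccc(C(F)(F)F)c1`, a toxicity assay on HepG2 cells (Homo sapiens) for cytotoxicity, read by MTT assay, with a stated time of 24 h; on this read-out lower numbers stand for higher toxicity in this test and higher numbers for lower toxicity in this test: "nd" (no result reported)
compound 2, `O=[N+]([O-])c1ccc2nc(Nc3cccc(Cl)c3)c(Nc3cccc(Cl)c3)nc2c1`, this assay: 6760 nM

Compound 1 has no single number in this assay, so it stands nowhere on the scale shown; compound 2 gives the only anchor with 6760 nM. The step to compound 3, `Nc1ccc2nc(Nc3ccc(Cl)c(Cl)c3)c(Nc3ccc(Cl)c(Cl)c3)nc2c1`, is hydrogen in place of (3-(trifluoromethyl)phenyl)carbonyl on a nitrogen on an aromatic ring. For the measured compounds named here, with no measured step for this pair, the size of the change in this assay is unknown; the expectation is a shift no larger than the scatter, in no firm direction, since the shared core is kept. Compound 3 is expected to give 8000 nM, within 2500 nM to 25000 nM.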

Compound 3, half-maximal cytotoxic concentration: 25100 nM
Estimate against measurement, compound 3: 3.1-fold (0.50 log units) below; the measured number lies above the stated range.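

No step can be read from the pair compound 1 and compound 3 in this assay. On these data alone, whether (3-(trifluoromethyl)phenyl)carbonyl on the aromatic nitrogen shifts this read-out stays open, and nothing available bears on the result for compound 3.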